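A few compounds are considered here, and "the series" means these few. Any claim that something is new, unique, unknown or untested is made for them only; others in the source may bear on it.

Working notes on the series, measured in a functional assay on cardiac atrium for agonist activity at histamine H2 receptor (Cavia porcellus); on this read-out lower numbers stand for an effect already at smaller amounts and higher numbers for an effect only at larger amounts of compound. Compound 1 `N=C(NCCCc1c[nH]cn1)NC(=O)CC(c1ccccc1)c1ccccn1` gives 51.3 nM. Compound 2 `N=C(NCCCc1c[nH]cn1)NC(=O)CC(c1ccccc1)c1nccs1` gives 38 nM in this assay; it differs from compound 1 by 1,3-thiazol-2-yl in place of pyridin-2-yl on a saturated chain carbon bound to an aromatic carbon and a saturated chain carbon, and the step is a 1.4-fold lower number from compound 1 to compound 2 (0.13 log units; within the scatter). Compound 3 `CC(CC(=O)NC(=N)NCCCc1c[nH]cn1)c1ccccn1` gives 38 nM in this assay; its core differs from that of compound 1 by methyl in place of phenyl on a saturated chain carbon bound to an aromatic carbon and a saturated chain carbon, a step of a 1.4-fold lower number from compound 1 to compound 3 (0.13 log units; within the scatter). Compound 4 `CC(CC(=O)NC(=N)NCCCc1c[nH]cn1)c1nccs1` is not yet measured. It differs from compound 3 by 1,3-thiazol-2-yl in place of pyridin-2-yl on a saturated chain carbon bound to two saturated chain carbons. This is the same kind of change as between compound 1 and compound 2, not the same: there the place was a saturated chain carbon bound to an aromatic carbon and a saturated chain carbon, here one bound to two saturated chain carbons. The step expected in this assay is a 1.3-fold lower number from compound 3 to compound 4 (0.10 log units; within the scatter), resting on the earlier step being a 1.4-fold lower number from compound 1 to compound 2 (0.13 log units; within the scatter). Compound 4 is therefore estimated at 30 nM, expected between 12 nM and 80 nM.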

Compound 4, half-maximal effective concentration: 38.9 nM
Compound 4: the middle estimate sits 1.3-fold (0.11 log units) below what was measured; measured number inside the range.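

1,3-Thiazol-2-yl in place of pyridin-2-yl, read on the core of compound 3, gives a 1.0-fold higher number from compound 3 to compound 4 (0.01 log units; within the scatter), and the two readings of this change agree in this assay: the same change on two cores in this assay, a 1.4-fold lower number (0.13 log units; within the scatter) from compound 1 to compound 2 and a 1.0-fold higher number (0.01 log units; within the scatter) from compound 3 to compound 4, 1.4-fold (0.14 log units) apart, within the scatter of two such steps
Methyl in place of phenyl, read on the core of compound 2, gives a 1.0-fold higher number from compound 2 to compound 4 (0.01 log units; within the scatter), and the two readings of this change also agree: the same change on two cores in this assay, a 1.4-fold lower number (0.13 log units; within the scatter) from compound 1 to compound 3 and a 1.0-fold higher number (0.01 log units; within the scatter) from compound 2 to compound 4, 1.4-fold (0.14 log units) apart, within the scatter of two such steps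
All four steps lie within the scatter, so the data show that neither change moves the number measurably on either core, but not that a step of real size would carry over from one core to another.

The compounds shown leave open whether a longer chain in place of methyl, or an amine or a carboxylic acid in place of the aromatic ring, would give a step beyond the scatter.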